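Bromo-to-formyl and dichlorophenyl swaps in one fused series

The source may report more compounds than this note shows. Statements on the series, on what has been measured and on what is new or still open speak of the compounds shown alone.

Measured so far in an ADME assay on CCRF-CEM cells (Homo sapiens) for cytotoxicity, with a stated time of 72 h; a lower number here means a stronger inhibitor, a higher number a weaker inhibitor:
Compound 1 `Cc1ccc(-c2nc3sc(Cc4ccc(Cl)cc4)nn3c2Br)cc1`: in this assay compound 1 reports only a limit, > 250000 nM.
Compound 2 `Clc1ccc(Cc2nn3c(Br)c(-c4ccc(Cl)cc4Cl)nc3s2)cc1`: in this assay compound 2 gives 106000 nM.
Compound 3 `Cc1ccc(-c2nc3sc(Cc4ccc(Cl)cc4)nn3c2C=O)cc1`: in this assay compound 3 gives 17000 nM.

Going by these compounds, from compound 1 to compound 2 the change is 2,4-dichlorophenyl in place of 4-methylphenyl on an aromatic carbon, and it gives an at least 2.3-fold lower number from compound 1 to compound 2 (0.37 log units; beyond the scatter); its true size stays open because compound 1 sits at the limit of > 250000 nM in this assay, at which 1 of the 3 values shown sits. From compound 1 to compound 3 the change is formyl in place of bromo on an aromatic carbon, with an at least 14-fold lower number from compound 1 to compound 3 (1.16 log units; beyond the scatter), and this is also how the core of compound 3 differs from that of compound 1. Compound 3 carries the lowest number of the two measured here.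

Compound 4 `O=Cc1c(-c2ccc(Cl)cc2Cl)nc2sc(Cc3ccc(Cl)cc3)nn12` is not yet measured. It differs from compound 3 by 2,4-dichlorophenyl in place of 4-methylphenyl on an aromatic carbon. This is the same kind of change as from compound 1 to compound 2, not the same: here the place is next to the ring atom that bears a formyl group (2 heavy atoms), there next to the ring atom that bears a bromo group (1 heavy atom).

Within the data shown here, for compound 4 the expected step is a 2.4-fold lower number from compound 3 to compound 4 (0.39 log units; beyond the scatter), set beside an at least 2.3-fold lower number from compound 1 to compound 2 (0.37 log units; beyond the scatter), which is the only measured instance of this change and is itself a limit. Compound 4 is estimated at 7000 nM, expected between 2500 nM and 25000 nM.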

Compound 4, half-maximal inhibitory concentration: 79000 nM
For compound 4 the middle estimate is 11-fold (1.05 log units) below the measured one; measured number above the stated range.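

In this assay, the change to 2,4-dichlorophenyl in place of 4-methylphenyl does not carry from one core to the other, with a 4.6-fold higher number from compound 3 to compound 4 (0.67 log units; beyond the scatter) running opposite to the step on the core of compound 1: the same change on two cores in this assay, an at least 2.3-fold lower number (0.37 log units; beyond the scatter) from compound 1 to compound 2 and a 4.6-fold higher number (0.67 log units; beyond the scatter) from compound 3 to compound 4, at least 10-fold (1.03 log units) apart, beyond the scatter of two such steps. The change to formyl in place of bromo does not carry either, with a 1.3-fold lower number from compound 2 to compound 4 (0.13 log units; within the scatter) on the cores bearing 2,4-dichlorophenyl: the same change on two cores in this assay, an at least 14-fold lower number (1.16 log units; beyond the scatter) from compound 1 to compound 3 and a 1.3-fold lower number (0.13 log units; within the scatter) from compound 2 to compound 4, at least 10-fold (1.03 log units) apart, beyond the scatter of two such steps. Each change therefore depends here on the group at the other place, but this does not show why, and both earlier steps keep an open size, as compound 1 reports only a limit: the limit of > 250000 nM in this assay, at which 1 of the 4 values shown sits.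

Going by these compounds, these four compounds form a single set of paired changes, so any wider rule for the series stays open. On these data alone, whether the same dependence would appear with a carboxylic acid or an amine at the place of the formyl group also stays open.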